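Working notes on compound 2 and the change to compound 4

The source may hold more compounds than are shown below. What is called first, only, known or untested is meant among the compounds shown, and "the series" means these compounds.

Three measured compounds share one core. Compound 1 `O=S(=O)(NCCNCc1ccc(-c2ccccc2)cc1)c1cc(C(F)(F)F)cc(C(F)(F)F)c1` gives 1400 nM in a functional assay on MCF7 cells (Homo sapiens) for inhibition, read by MTT assay, with a stated time of 72 h; on this read-out higher numbers stand for weaker inhibition of growth and lower numbers for stronger inhibition of growth. Compound 2 `O=S(=O)(NCCCNCc1cccc(Cl)c1)c1cc(C(F)(F)F)cc(C(F)(F)F)c1` gives 2600 nM in this assay. Compound 3 `O=S(=O)(NCCCNCc1ccc(-c2ccccc2)cc1)c1cc(C(F)(F)F)cc(C(F)(F)F)c1` gives 1700 nM in this assay. Compound 2 gives the highest of the three numbers, but its nearest neighbour, compound 3, and its furthest, compound 1, both lie within the usual scatter of it, so the three numbers read as one level rather than as a ranking.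

Compound 4 `COc1ccccc1CNCCCNS(=O)(=O)c1cc(C(F)(F)F)cc(C(F)(F)F)c1` has not yet been measured. It differs from compound 2 in one place: 2-methoxyphenyl in place of 3-chlorophenyl on a saturated chain carbon bound to an amine nitrogen.

Among the measured compounds shown here, no measured pair maps this change, so there is no step to lean on. The three values on hand show that swapping the group on the chain carbon bound to the amine nitrogen, from compound 2 to compound 3 or compound 1, moves the number only within the scatter. On that basis the step from compound 2 to compound 4 in this assay is expected to be small, with no clear direction, and the estimate is a 1.2-fold lower number from compound 2 to compound 4 (0.07 log units; within the scatter). Compound 4 is accordingly expected to give about 2200 nM in this assay, with a range from 800 nM to 6000 nM.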

Compound 4, concentration for 50% growth inhibition: 2600 nM
Beside the measured number, compound 4's estimate is 1.2-fold (0.07 log units) below it, within the range that was stated.
By their numbers in this assay, from the lowest: compounds 1, 3, 2 and 4 (each within the scatter of the next).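

In this assay, among the compounds shown here, the exchange of 3-chlorophenyl for 2-methoxyphenyl on a saturated chain carbon bound to an amine nitrogen gives no change at the digits printed from compound 2 to compound 4 (within the scatter) and is the first single-place step that can be read directly. The earlier compounds shown here offered no such step, whereas this pair shows that, with the rest of the molecule held constant, this position accepts a group with 1 hydrogen-bond acceptor in place of one with 0, and with oxygen in place of chlorine, without a shift beyond the scatter. No measured evidence explains this result or bears on it.

The compounds shown leave open whether a pyridine ring, a cyclohexyl group or a phenyl ring carrying a carboxylic acid would also leave the number in place on this chain carbon. They also leave open whether 2-methoxyphenyl would give the same reading on the chain of compound 1, or on a longer chain, since this change has been read only once and on a single chain.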